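Chloro Enters the Benzylsulfanyl Arm of a Shared Core

A few compounds are considered here, and "the series" means these few. Any claim that something is new, unique, unknown or untested is made for them only; others in the source may bear on it.

Measured compounds:
compound 1 `CC1=C(C(=O)Nc2ccc(F)cc2)C(c2ccc([N+](=O)[O-])cc2)N=C(SCc2ccc(Cl)cc2)N1`: 3.6%
compound 2 `CC1=C(C(=O)Nc2ccc([N+](=O)[O-])cc2)C(c2ccc(Br)cc2)N=C(SCc2ccccc2)N1`: 2.1%
compound 3 `CC1=C(C(=O)Nc2ccc([N+](=O)[O-])cc2)C(c2cccc([N+](=O)[O-])c2)N=C(SCc2ccccc2)N1`: 2.6%

In a functional assay on the whole organism (artery, strain albino) with Rattus norvegicus as the target, with a stated time of 15 min, at a dose of 10 mg/kg by the oral route (a higher number here means more inhibition at the dose given (going by the name of the read-out), a lower number less inhibition), compound 3 gives 2.6%, the second highest of the three numbers, with compound 2 nearest at 2.1% and compound 1 furthest at 3.6%, all three within the scatter of one another. Within the data shown here, the only measured step, a number 0.5 percentage points higher from compound 2 to compound 3 (within the scatter), is within the scatter and concerns a different place on the shared core. Compound 4 `CC1=C(C(=O)Nc2ccc([N+](=O)[O-])cc2)C(c2cccc([N+](=O)[O-])c2)N=C(SCc2ccc(Cl)cc2)N1` differs from compound 3 by chloro in place of hydrogen on an aromatic carbon. Among the measured compounds shown here, no measured step bears on this change; compound 1 carries a 4-chlorobenzyl group but differs from compound 3 elsewhere as well. A step of a number 0.4 percentage points higher from compound 3 to compound 4 (within the scatter) is therefore expected, none beyond the scatter. Compound 4 is estimated at 3%, in the range 0% to 8%.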

Compound 4, a percentage reported as inhibition, in the whole organism at one dose (the size of the read-out at that dose, not a potency): 2.1%
For compound 4 the middle estimate is 0.9 percentage points above the measured one, within the range that was stated.
By their numbers in this assay, from the lowest: compounds 2, 4, 3 and 1 (each within the scatter of the next).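

In this assay, chloro in place of hydrogen on the aromatic ring of the benzylsulfanyl arm gives a number 0.5 percentage points lower from compound 3 to compound 4 (within the scatter). Among these compounds, this is the only reading of the change with the rest of the shared core held constant, and at this dose benzyl and 4-chlorobenzyl stand within the scatter of each other. Nothing measured here offers an explanation for this result. As far as these compounds go, whether an amine or a carboxylic acid at the same place on the ring, or a longer chain in place of benzyl on the sulfur, would move the read-out beyond the scatter stays open.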